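Three analogues at the assay limit and a fourth expected there

The source may hold more compounds than are shown below. What is called first, only, known or untested is meant among the compounds shown, and "the series" means these compounds.

Measured compounds:
compound 1 `COc1ccc(Cc2cc(-c3ccc(C)cc3)nn(CC(=O)Nc3ccc(Br)cc3)c2=O)cc1`: > 50000 nM, a limit of the assay
compound 2 `COc1cccc(Cc2cc(-c3ccc(C)cc3)nn(CC(=O)Nc3ccc(F)cc3)c2=O)c1`: > 50000 nM, a limit of the assay
compound 3 `COc1ccc(Cc2cc(-c3ccc(F)cc3)nn(CC(=O)Nc3ccc(Br)cc3)c2=O)cc1`: > 50000 nM, a limit of the assay

In an assay on HL-60 cells for agonist activity at N-formyl peptide receptor 3 (Homo sapiens), read by calcium flux (a higher number here means that more compound is needed for the effect, a lower number that less compound is needed), compound 1 reports only a limit. Compound 3 differs from compound 1 by fluoro in place of methyl on an aromatic carbon, and the step that the two limits leave unreadable from compound 1 to compound 3. The difference between the core of compound 2 and the core of compound 1 is not broken down here. Compound 4 `COc1cccc(Cc2cc(-c3ccc(F)cc3)nn(CC(=O)Nc3ccc(F)cc3)c2=O)c1` differs from compound 2 by the same change, (fluoro in place of methyl on an aromatic carbon). Because (the limit of > 50000 nM in this assay, at which 3 of the 3 values shown sit), no shift is readable for this change, and the same is expected for compound 4. Compound 4 is estimated at 80000 nM, most likely again reported only as a limit. The expected step that the limit leaves unreadable from compound 2 to compound 4 rests on compound 1 and compound 3 both sitting at the limit of > 50000 nM in this assay, at which 3 of the 3 values shown sit.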

Compound 4, half-maximal effective concentration: > 50000 nM
Compound 4 was reported as a limit; the forecaster's own chance of this, stated with the estimate: 90%; the middle value is on the limit's open side.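

Compound 2 and compound 4 both stand at a limit of the assay, and no size can be read for the step between them in this assay. The compounds shown leave open whether any analogue of the shared core gives a measurable response.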